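This account rests on a few compounds, and the source may have more. Where it says the series, first, only, none or still open, it means among the compounds named here.

Compound 1, `CCCCCc1cc(Nc2ccc(OC)cc2)cc(=O)o1`, was tested in a functional assay on SK-BR-3 cells (Homo sapiens) for cytotoxicity, read by MTT assay, with a stated time of 72 h (a higher number here means that more compound is needed for the effect, a lower number that less compound is needed), where compound 1 gives 4.93 uM. Among the two numbers recorded, compound 1 stands highest. Within the data shown here, the only other measured compound is compound 2, `COc1ccccc1Nc1cc(-c2ccccc2)oc(=O)c1`, which in this assay gives 0.54 uM; the two compounds differ in more than one place, so no single step connects them, and what their values show is that compound 2 needs a lower concentration than compound 1, by a margin beyond the scatter.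

The next compound, compound 3, `COc1ccc(Nc2cc(C(C)C)oc(=O)c2)cc1`, is still to be measured in this assay. It differs from compound 1 in one place: isopropyl in place of pentyl on an aromatic carbon of the shared core. Among the measured compounds shown here, no measured pair shows what such a shortening of the chain does here, so the expectation rests on compound 1 alone. The step is expected to be small, a 1.4-fold higher number from compound 1 to compound 3 (0.15 log units; within the scatter), and to stay within the scatter, with a mild lean toward a higher number. On that basis compound 3 is estimated at 7 uM, within a range from 2.5 uM to 20 uM.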

Compound 3, concentration for half-maximal effect: > 30 uM
Compound 3 ended at the assay's limit (the forecaster's own chance of this, stated with the estimate: 5%); middle value at least 4.2-fold (0.63 log units) from the limit.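

Compound 3 gives > 30 uM in this assay, which is a limit of the assay and not a number: the limit of > 30 uM in this assay, at which 1 of the 3 values shown sits.

Even so, the change can be read, and it gives the first single step available at any place on the shared core: isopropyl in place of pentyl on the aromatic carbon next to the ring oxygen brings an at least 6.0-fold higher number from compound 1 to compound 3 (0.78 log units; beyond the scatter). The earlier compounds shown here could not show this, since compound 1 and compound 2 differ in more than one place, whereas this pair shows that the group at this position can by itself move the cytotoxicity reading beyond the scatter, with the shorter branched group on the side of the higher number.

A single pair cannot separate the length of the chain from its branching, so a straight propyl group, a butyl group or a longer chain such as heptyl at this place would be needed to tell the two apart. From the compounds shown here alone, whether a cyclohexyl ring here would behave like pentyl or like isopropyl also remains open, as does whether the step holds with a different group on the nitrogen of the shared core.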